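Trading Ethoxycarbonyl for Isopropoxycarbonyl in Compound 1

This account rests on a few compounds, and the source may have more. Where it says the series, first, only, none or still open, it means among the compounds named here.

Compound 1, `CCOC(=O)C1=C(C)NC(=O)NC1C1CCCC1`, was tested in an assay on cells for displacement of a labelled ligand from adenosine receptor A1 (Homo sapiens), with a stated time of 60 min, tested at 1 uM (a higher number here means more inhibition at the concentration tested (going by the name of the read-out), a lower number less inhibition), where compound 1 gives 3%. Compound 2, `CC1=C(C(=O)OC(C)C)C(C2CCCC2)N/C(=N/C#N)N1`, gives 3% in this assay, so compound 1 stands level with compound 2 at the digits shown, the two values lying within the usual scatter of one another. Compound 3, `CC1=C(C(=O)OC(C)C)C(C2CCCC2)NC(=O)N1`, has not yet been measured. It differs from compound 1 by one change only: methyl in place of hydrogen on a saturated chain carbon bound to an oxygen next to a carbonyl group and a saturated chain carbon. Among the compounds with values here, no pair of measured compounds separated by a single change is available, so there is no measured step to lean on. With both measured compounds sitting at the same low level, no shift beyond the scatter is expected in either direction for compound 3. The change implied by this estimate, a number 1 percentage points higher from compound 1 to compound 3 (within the scatter), is expected to stay within the scatter. Compound 3 is estimated to give 4%, within a range from -5% to 15%.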

Compound 3, a percentage reported as inhibition, at one concentration (the size of the read-out at that concentration, not a potency): 1%
Compound 3: middle estimate off by 3 percentage points, on the high side; the measured number falls inside the stated range.
By their numbers in this assay, from the lowest: compounds 3, 1 and 2 (each within the scatter of the next).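

Within the data shown here, this is the first single change that can be read directly: swapping ethoxycarbonyl for isopropoxycarbonyl gives, in this assay, a number 2 percentage points lower from compound 1 to compound 3 (within the scatter), so the two compounds cannot be told apart. Adding a methyl on this saturated chain carbon bound to an oxygen therefore brings no measurable inhibition at the concentration tested, although both compounds sit so low that the comparison says little about how much this position matters. No further measurement bears on this result.

From the compounds shown here alone, whether a longer chain such as butyl on that oxygen, or a carboxylic acid or an amide in place of the ethoxycarbonyl, would read any differently remains open. Going by these compounds, it is also open whether the same methyl would matter on a compound with clear inhibition in this assay.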